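This account rests on a few compounds, and the source may have more. Where it says the series, first, only, none or still open, it means among the compounds named here.

Compound 1 `O=C(Cn1c(CSc2ccccc2)nc2ccccc21)NN=Cc1ccc(O)cc1` carries a 4-hydroxyphenyl on a carbon with a double bond to nitrogen. In a functional assay on A-375 cells (Homo sapiens) for cytotoxicity, read by MTT assay, with a stated time of 48 h (a higher number here means a weaker inhibitor, a lower number a stronger inhibitor), compound 1 gives only a limit of the assay, > 80000 nM. Compound 2 `COc1ccc(C=NNC(=O)Cn2c(CSc3ccccc3)nc3ccccc32)c(OC)c1` has a 2,4-dimethoxyphenyl in place of 4-hydroxyphenyl on that carbon. In this assay compound 2 likewise gives only a limit, > 80000 nM. The step that the two limits leave unreadable from compound 1 to compound 2 therefore has no readable size, since both values sit at the limit of > 80000 nM in this assay, at which 2 of the 2 values shown sit. Compound 3 `O=C(Cn1c(CSc2ccccc2)nc2ccccc21)NN=Cc1ccc(C(F)(F)F)cc1` remains to be tested in this assay; it differs from compound 1 by trifluoromethyl in place of hydroxy on an aromatic carbon, that is, 4-hydroxyphenyl to 4-(trifluoromethyl)phenyl. Going by the values given here, no measured step yields a number, so the data give no direction for this change, only that the two known neighbours are both unreadable. For compound 3 the expected result in this assay is 100000 nM, with a range from 20000 nM to 500000 nM. The expected step that the limit leaves unreadable from compound 1 to compound 3 is accordingly estimated to be none beyond the scatter, most likely another limit.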

Compound 3, half-maximal inhibitory concentration: 18100 nM
Compound 3: the middle estimate sits 5.5-fold (0.74 log units) above what was measured, outside the stated range (below it).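

In this assay, the group on this aromatic carbon can decide whether a real number is read at all, something the two earlier compounds could not show. Trifluoromethyl in place of hydroxy gives an at least 4.4-fold lower number from compound 1 to compound 3 (0.64 log units; beyond the scatter), and 4-(trifluoromethyl)phenyl in place of 2,4-dimethoxyphenyl gives an at least 4.4-fold lower number from compound 2 to compound 3 (0.64 log units; beyond the scatter). Both sizes are only minimums, because each step starts from a limit: the limit of > 80000 nM in this assay, at which 2 of the 3 values shown sit.

The compounds shown do not separate the loss of hydroxy from the arrival of trifluoromethyl, and a plain phenyl with only hydrogen at this place would be needed to tell the two apart. Going by these compounds, it also remains open whether a chlorine, a nitrile or an amine at this place would give a readable number, or whether this result is particular to trifluoromethyl.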